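This account rests on a few compounds, and the source may have more. Where it says the series, first, only, none or still open, it means among the compounds named here.

Measured compounds:
compound 1, `Cc1ccc2nc(-c3ccc(NCc4cn(Cc5cc(=O)oc6cc(O)ccc56)nn4)cc3)sc2c1`, 10500 nM;
compound 2, `Cc1ccc2c(Cn3cc(CNc4ccc(-c5nc6ccc(C)cc6s5)cc4)nn3)cc(=O)oc2c1`, 34900 nM;
compound 3, `Cn1c(-c2cn(Cc3cc(=O)oc4cc(O)ccc34)nn2)nc2ccccc21`, 76500 nM.

All three were tested in a functional assay on CFPAC-1 cells (Homo sapiens) for inhibition, read by MTT assay, with a stated time of 72 h; a higher number here means a weaker inhibitor, a lower number a stronger inhibitor. Compound 1 and compound 2 share one core and differ only in one change, (methyl in place of hydroxy on an aromatic carbon), which made a step of a 3.3-fold higher number from compound 1 to compound 2 (0.52 log units; beyond the scatter). Compound 3 has a different core; how the core of compound 3 differs from the core of compound 1 is not broken down here. Compound 4, `Cc1ccc2c(Cn3cc(-c4nc5ccccc5n4C)nn3)cc(=O)oc2c1`, is not yet measured; it differs from compound 3 by methyl in place of hydroxy on an aromatic carbon, the same change at the same kind of place as between compound 1 and compound 2. Because the earlier step was a 3.3-fold higher number from compound 1 to compound 2 (0.52 log units; beyond the scatter), a similar weakening is expected here, a 2.9-fold higher number from compound 3 to compound 4 (0.46 log units; beyond the scatter). Compound 4 is therefore estimated at 220000 nM, expected to fall between 80000 nM and 600000 nM.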

Compound 4, half-maximal inhibitory concentration: 59400 nM
Beside the measured number, compound 4's estimate is 3.7-fold (0.57 log units) above it, outside the stated range (below it).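

On the core of compound 3, methyl in place of hydroxy gave a 1.3-fold lower number from compound 3 to compound 4 (0.11 log units; within the scatter) in this assay, so the weakening seen on the other core did not reappear. The two steps differ by more than repeated measurements would normally scatter: the same change on two cores in this assay, a 3.3-fold higher number (0.52 log units; beyond the scatter) from compound 1 to compound 2 and a 1.3-fold lower number (0.11 log units; within the scatter) from compound 3 to compound 4, 4.3-fold (0.63 log units) apart, beyond the scatter of two such steps

In this series, then, the size of this change depends on the core, but two pairs cannot show which feature of the cores matters or how the change would behave on a third core. Only hydroxy and methyl appear on this aromatic carbon among the compounds shown, so how a methoxy group or an amine there would behave on either core remains open.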